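Changing the ring group on the lactam side chain

The source may report more compounds than this note shows. Statements on the series, on what has been measured and on what is new or still open speak of the compounds shown alone.

Measured compounds:
compound 1, `O=C1[C@@H](NS(=O)(=O)c2cc3cccnc3s2)CCN1Cc1cc2[nH]cccc-2n1`: 44%
compound 2, `O=C1[C@@H](NS(=O)(=O)c2cc3cccnc3s2)CCN1Cc1cc2c[nH]ccc-2n1`: 18%

In an assay on isolated protein for inhibition of coagulation factor X (Oryctolagus cuniculus), tested at 1 uM (a higher number here means more inhibition at the concentration tested (going by the name of the read-out), a lower number less inhibition), compound 1 gives 44%, and compound 2 gives 18%. Going by the values given here, compound 2 is the lower of the two numbers; the only measured step leading to it, a number 26 percentage points lower from compound 1 to compound 2 (beyond the scatter), swaps one bicyclic group for a closely related one on the carbon next to the ring amide nitrogen, and it is the one step that bears on the present question.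

Compound 3, `O=C1[C@@H](NS(=O)(=O)c2cc3cccnc3s2)CCN1CCNc1ccncc1`, has not yet been measured in this assay. It differs from compound 2 in the same place: a group of 8 heavy atoms (6 carbon, 2 nitrogen; one six-membered aromatic ring with 1 hetero atom) in place of a group of 9 heavy atoms (7 carbon, 2 nitrogen; one five-membered aromatic ring with 1 hetero atom, one six-membered aromatic ring with 1 hetero atom), on a saturated chain carbon bound to an amide-type nitrogen in a ring. Here the group that enters is a single six-membered aromatic ring carried on an amino-methyl link rather than a fused pair of rings, so the measured step gives only a rough guide to the size of change such a swap can bring, which was modest. No direct comparison for this kind of group exists among the measured compounds, so the expectation is uncertain and centred near compound 2. Compound 3 is expected to give about 25% in this assay, within 5% to 55%, which is estimated as a number 7 percentage points higher from compound 2 to compound 3 (within the scatter).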

Compound 3, a percentage reported as inhibition, at one concentration (the size of the read-out at that concentration, not a potency): 23%
Compound 3: the middle estimate sits 2 percentage points above what was measured; the measured number falls inside the stated range.
By their numbers in this assay, from the lowest: compounds 2 and 3 (each within the scatter of the next); then compound 1.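

In this assay, the fused pair of rings turns out not to be needed to reach the level of compound 2: swapping it for the ((pyridin-4-yl)amino)methyl group, which carries one six-membered aromatic ring, gives a number 5 percentage points higher from compound 2 to compound 3 (within the scatter). The same group set against the fused group of the other compound gives a number 21 percentage points lower from compound 1 to compound 3 (beyond the scatter), so at this place, on a saturated chain carbon bound to an amide-type nitrogen in a ring, two quite different groups read alike, and only the group of compound 1 stands apart from them. Nothing measured here explains why the group of compound 1 stands apart or why such different groups read alike.

The ((pyridin-4-yl)amino)methyl group differs from the fused groups in both its ring and its link, so the compounds shown leave open which of the two matters for this number. A phenyl ring on the same amino-methyl link, or a longer chain carrying the same pyridine ring, would begin to separate those two parts of the change.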